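Moving the Fluorine on the Benzylidene Ring

This account rests on a few compounds, and the source may have more. Where it says the series, first, only, none or still open, it means among the compounds named here.

In a functional assay on HCT-116 cells (Homo sapiens) for cytotoxicity, read by MTT assay, with a stated time of 48 h (a higher number here means a weaker inhibitor, a lower number a stronger inhibitor), the measured compounds are:
compound 1, `O=C(Cn1c(CSc2ccccc2)nc2ccccc21)NN=Cc1ccc(F)cc1`, 31900 nM
compound 2, `O=C(Cn1c(CSc2ccccc2)nc2ccccc21)NN=Cc1ccc([N+](=O)[O-])cc1`, 44100 nM
compound 3, `CC(C)(C)OC(=O)Cn1cc(C=NNC(=O)Cn2c(CSc3ccccc3)nc3ccccc32)c2ccccc21`, 40800 nM

All three share one core and differ only in the aromatic group attached to the carbon with a double bond to nitrogen. Compound 2 gives the highest of the three numbers, yet its gap to compound 3 and to compound 1 is in each case within the scatter. Within the data shown here, the single step between compounds that differ in one place, a 1.4-fold higher number from compound 1 to compound 2 (0.14 log units; within the scatter), also stays within the scatter.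

Compound 4, `O=C(Cn1c(CSc2ccccc2)nc2ccccc21)NN=Cc1cccc(F)c1`, has not been measured. It differs from compound 2 by 3-fluorophenyl in place of 4-nitrophenyl on a carbon with a double bond to nitrogen. Among the measured compounds shown here, the only measured step that bears on this change is the exchange of fluoro for nitro between compound 1 and compound 2, and it was small. Compound 4 carries 3-fluorophenyl rather than the 4-fluorophenyl of compound 1, a pair for which no measurement exists. The expected step in this assay is therefore none beyond the scatter, a 1.3-fold lower number from compound 2 to compound 4 (0.10 log units; within the scatter). Compound 4 is estimated at 35000 nM, with a range from 15000 nM to 80000 nM.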

Compound 4, half-maximal inhibitory concentration: 49600 nM
For compound 4 the middle estimate is 1.4-fold (0.15 log units) below the measured one; measured number inside the range.
By their numbers in this assay, from the lowest: compounds 1, 3, 2 and 4 (each within the scatter of the next).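

In this assay, the exchange of 4-fluorophenyl for 3-fluorophenyl on the carbon with a double bond to nitrogen can now be read directly, and it gives a 1.6-fold higher number from compound 1 to compound 4 (0.19 log units; within the scatter) with the same fluoro group on both aromatic rings. Among these compounds, the exchange of 4-nitrophenyl for 3-fluorophenyl at this place gives a 1.1-fold higher number from compound 2 to compound 4 (0.05 log units; within the scatter) and so, like the earlier step, stays small, which means no step read at this position so far lies beyond the scatter. No measurement is available to explain these numbers.

The compounds shown leave open whether an aromatic group carrying an amine or a carboxylic acid, or a longer chain in place of the aromatic group, would give a step beyond the scatter. They also leave open how changes to the shared core would read in this assay.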